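The source may hold more compounds than are shown below. What is called first, only, known or untested is meant among the compounds shown, and "the series" means these compounds.

Compound 1 `CCN1CCN(CCCn2cnc3c(N4CCN(CC)CC4)nc(N)nc32)CC1` is the parent of this small series. In an assay on HEK293 cells for antagonist activity at Toll-like receptor 9 (Homo sapiens), read by spectrophotometry (a higher number here means a weaker inhibitor, a lower number a stronger inhibitor), compound 1 gives 260 nM, the lowest of the three numbers, though all three lie within the usual scatter of one another. Compound 2 `CCN1CCN(CCCn2cnc3c(N4CCN(CC)CC4)nc(NCc4ccc(N(CC)CC)cc4)nc32)CC1` gives 440 nM, and the step of a 1.7-fold higher number from compound 1 to compound 2 (0.23 log units; within the scatter) comes from adding 4-(diethylamino)benzyl on the amino nitrogen. Compound 3 `CCN1CCN(CCCn2cnc3c(N4CCN(C5CCCC5)CC4)nc(N)nc32)CC1` gives 280 nM, and the step of a 1.1-fold higher number from compound 1 to compound 3 (0.03 log units; within the scatter) comes from cyclopentyl in place of ethyl on the ring amine nitrogen. Compound 4 `CCN1CCN(c2nc(N)nc3c2ncn3CCCN2CCCC2)CC1` changes a third place: pyrrolidin-1-yl in place of 4-ethylpiperazin-1-yl on a saturated chain carbon, three bonds along the chain from an aromatic nitrogen. Neither measured step touches the chain end, so they bear only indirectly on this change; both show that the shared core tolerates edits at two other positions without a step beyond the scatter. On that basis, the step of a 1.3-fold higher number from compound 1 to compound 4 (0.13 log units; within the scatter) is expected to stay within the scatter, perhaps drifting slightly toward a higher number. Compound 4 is therefore estimated at 350 nM, within a range from 150 nM to 900 nM.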

Compound 4, half-maximal inhibitory concentration: 190 nM
For compound 4 the middle estimate is 1.8-fold (0.27 log units) above the measured one; the range from low to high includes it.
By their numbers in this assay, from the lowest: compounds 4, 1, 3 and 2 (each within the scatter of the next, the first and the last beyond it).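

The chain end, which neither earlier step touched, now has a reading of its own in this assay: with a 1.4-fold lower number from compound 1 to compound 4 (0.14 log units; within the scatter), pyrrolidin-1-yl can stand in place of 4-ethylpiperazin-1-yl on this saturated chain carbon without a step beyond the scatter. This place therefore accepts a five-membered non-aromatic ring with 1 hetero atom where a six-membered non-aromatic ring with 2 hetero atoms stood, so all three places edited on the shared core have now given steps within the scatter. No supporting evidence bears on this result, so the reading of the change stands without an explanation.

The compounds shown leave open how a piperidine ring, a morpholine ring, an open dimethylamino group or a longer chain would read at this place. They also leave open whether pyrrolidin-1-yl would hold its reading when combined with the cyclopentyl or 4-(diethylamino)benzyl edits.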